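Nitro in Place of Fluoro: Expected Cytotoxicity of Compound 4

A few compounds are considered here, and "the series" means these few. Any claim that something is new, unique, unknown or untested is made for them only; others in the source may bear on it.

Compound 1 `O=c1ccoc2cc(OCc3cn(Cc4cccc(Br)c4)nn3)ccc12` gives > 300000 nM, a limit of the assay. Compound 2 `Cc1ccccc1Cn1cc(COc2ccc3c(=O)ccoc3c2)nn1` gives > 300000 nM, likewise a limit. Compound 3 `O=c1ccoc2cc(OCc3cn(Cc4cccc(F)c4)nn3)ccc12` gives > 300000 nM, again a limit.

In an ADME assay on L02 cells (Homo sapiens) for cytotoxicity, read by MTT assay, with a stated time of 48 h (a higher number here means a weaker inhibitor, a lower number a stronger inhibitor), compound 3 therefore stands at the limit and not at a number; all three values sit at the limit of > 300000 nM in this assay, at which 3 of the 3 values shown sit. Compound 4 `O=c1ccoc2cc(OCc3cn(Cc4cccc([N+](=O)[O-])c4)nn3)ccc12` differs from compound 3 by nitro in place of fluoro on an aromatic carbon. The steps a step that the two limits leave unreadable from compound 1 to compound 3 and a step that the two limits leave unreadable from compound 2 to compound 3 bear on this change, but both are unreadable. Going by the values given here, no measured step gives a readable size, so no step beyond the scatter is expected for compound 4, and it is estimated to remain at the limit: 300000 nM, in the range 100000 nM to 1000000 nM, a step of a number no higher from compound 3 to compound 4 (the limit leaves the size open).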

Compound 4, half-maximal inhibitory concentration: > 300000 nM
Compound 4: no number, only a limit; the forecaster's own chance of this, stated with the estimate: 85%; the middle value lies on the limit itself.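

No new step can be read between compound 4 and compounds 1, 2 and 3, because every value is a limit: the limit of > 300000 nM in this assay, at which 4 of the 4 values shown sit. The compounds shown leave open whether these four compounds differ at all in this assay.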